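Working notes: the group on the aromatic nitrogen of compound 2

This account rests on a few compounds, and the source may have more. Where it says the series, first, only, none or still open, it means among the compounds named here.

Measured in a functional assay on DU-145 cells (Homo sapiens) for cytotoxicity, read by MTT assay, with a stated time of 48 h; a lower number here means a stronger inhibitor, a higher number a weaker inhibitor:
- compound 1 `C#CC1=CC[C@@]2(C)C(=C)CCC[C@]2(C)CC1`: 387000 nM
- compound 2 `C=C1CCC[C@]2(C)CCC(c3cn(-c4ccc(OC)cc4)nn3)=CC[C@@]12C`: 58900 nM
- compound 3 `C=C1CCC[C@]2(C)CCC(c3cn(-c4cccc([N+](=O)[O-])c4)nn3)=CC[C@@]12C`: 62500 nM

Compound 2 stands level with compound 3 within the scatter, and both carry much lower numbers than compound 1. The next compound to read is compound 4 `C=C1CCC[C@]2(C)CCC(c3cn(-c4ccccc4C(C)=O)nn3)=CC[C@@]12C`, which has 2-acetylphenyl in place of the 4-methoxyphenyl of compound 2 on an aromatic nitrogen: 2-acetylphenyl in place of 4-methoxyphenyl on an aromatic nitrogen. Both groups hold one six-membered aromatic ring of carbon only, and the entering group adds a double bond outside aromatic rings.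

For the measured compounds named here, only one measured step bears on this change. It is a 1.1-fold higher number from compound 2 to compound 3 (0.03 log units; within the scatter), where 3-nitrophenyl replaces 4-methoxyphenyl on the same nitrogen. Going by the values given here, no measured compound carries 2-acetylphenyl, so this single step is thin support. Among the compounds with values here, with it as the only guide, no shift beyond the scatter is expected in this assay, and no direction can be given. The expected step is a 1.0-fold higher number from compound 2 to compound 4 (0.01 log units; within the scatter). For compound 4 the estimated value is 60000 nM, with an expected range from 28000 nM to 130000 nM.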

Compound 4, half-maximal inhibitory concentration: 48500 nM
Compound 4: middle estimate off by 1.2-fold (0.09 log units), on the high side, within the range that was stated.
By their numbers in this assay, from the lowest: compounds 4, 2 and 3 (each within the scatter of the next); then compound 1.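

In this assay the change to 2-acetylphenyl gives a 1.2-fold lower number from compound 2 to compound 4 (0.08 log units; within the scatter) and a 1.3-fold lower number from compound 3 to compound 4 (0.11 log units; within the scatter), so a third substituted phenyl group on the aromatic nitrogen of the five-membered ring stands level with the first two. The 1-position group can therefore differ in its substituent and in where that substituent sits on the phenyl ring, and can take on a double bond outside aromatic rings, with no step beyond the scatter among compound 2, compound 3 and compound 4. In these three compounds the substituent and its place change together, so the flat reading covers the pair of changes and does not separate one from the other, and no accompanying measurement helps to interpret this flat reading.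

Still open, going by these compounds, is whether a phenyl ring carrying a primary amine or a carboxylic acid would give a step beyond the scatter at this nitrogen. Also open, on these data alone, is whether replacing the phenyl ring with a longer alkyl chain, or moving the acetyl group to the 4-position of the ring, would do so.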